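The source may hold more compounds than are shown below. What is called first, only, known or untested is meant among the compounds shown, and "the series" means these compounds.

Measured compounds and their values:

Compound 1, `CCCCNc1cnc(C(=O)NCc2ccccc2)cn1`, in an ADME assay on HeLa cells (Homo sapiens) for cytotoxicity, read by microscopy, with a stated time of 6 days (on this read-out higher numbers stand for lower toxicity in this test and lower numbers for higher toxicity in this test), gives a limit of the assay, > 100000 nM.
Compound 2, `CCCCCCCCNc1cnc(C(=O)NCc2ccccc2)cn1`, in this assay gives 100000 nM.
Compound 3, `CCCCNc1cncc(C(=O)NCc2ccccc2)n1`, in this assay gives a limit of the assay, > 100000 nM.

The three compounds share a benzylamide attached to an aromatic ring that carries a chain-bearing nitrogen; compound 1 and compound 3 are built from the same atoms joined differently, and the difference between the two cores is not broken down here. Compound 1 and compound 2 differ by one change, (butyl in place of hydrogen on a saturated chain carbon, four bonds along the chain from a nitrogen on an aromatic ring). The step of a number no higher from compound 1 to compound 2 (the limit leaves the size open) shows that lengthening the chain in this way left the value at or near the limit (the limit of > 100000 nM in this assay, at which 2 of the 3 values shown sit), so the measured pair gives no sign of a rise in toxicity that can be sized.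

Compound 4, `CCCCCCCCNc1cncc(C(=O)NCc2ccccc2)n1`, is not yet measured. It stands to compound 3 as compound 2 stands to compound 1: the change is butyl in place of hydrogen on a saturated chain carbon, four bonds along the chain from a nitrogen on an aromatic ring, the same change as before, at the same place on the chain. Since compound 3 sits at the limit of > 100000 nM in this assay, at which 2 of the 3 values shown sit, like compound 1, and the measured step is a number no higher from compound 1 to compound 2 (the limit leaves the size open), the expected step is a number no higher from compound 3 to compound 4 (the limit leaves the size open), a value that again stays at or near the limit rather than moving. Compound 4 is therefore expected to give about 100000 nM in this assay, with a likely range from 50000 nM to 200000 nM, and a real chance that only a limit is reported.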

Compound 4, minimum cytotoxic concentration: > 100000 nM
Compound 4: no number, only a limit (the forecaster's own chance of this, stated with the estimate: 50%); the middle value sits exactly at the limit.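

In this assay compound 4 gives > 100000 nM, which is a limit of the assay and not a number. Compound 3 also stands at a limit, so the step between compound 3 and compound 4 cannot be read. The compounds shown leave open whether the longer chain changes toxicity at all on the core of compound 3, with the values gathered at one end of the scale: the limit of > 100000 nM in this assay, at which 3 of the 4 values shown sit.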